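This account rests on a few compounds, and the source may have more. Where it says the series, first, only, none or still open, it means among the compounds named here.

Measured so far:
- compound 1, `Cc1ncc([N+](=O)[O-])n1CCSc1nnc(-c2ccccc2)o1`: 20500 nM
- compound 2, `Cc1ncc([N+](=O)[O-])n1CCSc1nnc(-c2ccc(N)cc2)o1`: 19800 nM
- compound 3, `Cc1ncc([N+](=O)[O-])n1CCSc1nnc(-c2ccccc2O)o1`: 28300 nM

These three compounds were tested in a functional assay on MCF7 cells (Homo sapiens) for cytotoxicity, read by MTT assay, with a stated time of 48 h; a higher number here means a weaker inhibitor, a lower number a stronger inhibitor. Compound 1 has the second highest of the three numbers; its nearest neighbour is compound 2, with a 1.0-fold lower number from compound 1 to compound 2 (0.02 log units; within the scatter), and its furthest is compound 3, with a 1.4-fold higher number from compound 1 to compound 3 (0.14 log units; within the scatter). Both steps lie within the scatter, so the three numbers cannot be told apart with confidence.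

Compound 4, `Cc1ncc([N+](=O)[O-])n1CCSc1nnc(-c2ccnc(Cl)c2)o1`, is still to be measured. It differs from compound 1 by 2-chloropyridin-4-yl in place of phenyl on an aromatic carbon. The measured steps that come closest are those from compound 1, where an amino group or a hydroxy group was added to the phenyl ring: a 1.0-fold lower number from compound 1 to compound 2 (0.02 log units; within the scatter) and a 1.4-fold higher number from compound 1 to compound 3 (0.14 log units; within the scatter). Neither moved the number beyond the scatter. Going by the values given here, no measured step replaces the phenyl ring as a whole, so the change to the 2-chloropyridin-4-yl group is untested here.

Given that nothing on this ring has yet shifted the number, compound 4 is expected to give about 20000 nM, within 8000 nM to 50000 nM, which means an expected step of a 1.0-fold lower number from compound 1 to compound 4 (0.01 log units; within the scatter), no larger than the scatter.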

Compound 4, half-maximal inhibitory concentration: 40500 nM
Compound 4: the middle estimate sits 2.0-fold (0.31 log units) below what was measured; measured number inside the range.
By their numbers in this assay, from the lowest: compounds 2, 1, 3 and 4 (each within the scatter of the next, the first and the last beyond it).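

Going by these compounds alone, replacing the whole ring with 2-chloropyridin-4-yl gives the first step at this position that clears the scatter in this assay, though it does so modestly and against only one neighbour: a 2.0-fold higher number from compound 2 to compound 4 (0.31 log units; beyond the scatter). Against the other two compounds the change stays within the scatter, with a 2.0-fold higher number from compound 1 to compound 4 (0.30 log units; within the scatter) and a 1.4-fold higher number from compound 3 to compound 4 (0.16 log units; within the scatter), so this position accepts a ring with a hetero atom and a chlorine without a clear shift from the plain phenyl. No measurement shown here accounts for the one step beyond the scatter.

The new ring brings in a ring nitrogen and a chlorine together, so the compounds shown cannot separate what each contributes. Plain pyridin-4-yl and 4-chlorophenyl would pull the two apart, while a carboxylic acid on the ring remains an open question.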